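Swapping methoxy for chloro on the pendant phenyl ring

The source may report more compounds than this note shows. Statements on the series, on what has been measured and on what is new or still open speak of the compounds shown alone.

Compound 3, `CNC(=O)c1cc(C(=O)N[C@H]2CC[C@H](O)CC2)c([C@@H](C)c2cccc(OC)c2)o1`, is measured in an ADME assay for permeability (on this read-out lower numbers stand for lower permeability and higher numbers for higher permeability), and gives 44 nm/s, the lowest of the three numbers seen so far. Compound 1, `CNC(=O)c1cc(C(=O)N[C@H]2CC[C@H](O)CC2)c([C@@H](C)c2ccc(Cl)cc2)o1`, gives 150 nm/s, and compound 2, `CNC(=O)c1cc(C(=O)N[C@H]2CC[C@H](O)CC2)c([C@@H](C)c2ccccc2Cl)o1`, gives 78 nm/s. The step of a 3.4-fold lower number from compound 1 to compound 3 (0.53 log units; beyond the scatter) lies beyond the scatter, while a 1.8-fold lower number from compound 2 to compound 3 (0.25 log units; within the scatter) and a 1.9-fold lower number from compound 1 to compound 2 (0.28 log units; within the scatter) do not.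

Compound 4, `CNC(=O)c1cc(C(=O)N[C@H]2CC[C@H](O)CC2)c([C@@H](C)c2cccc(Cl)c2)o1`, differs from compound 3 in one place: chloro in place of methoxy on an aromatic carbon. Among the compounds with values here, no measured step makes exactly this change. The two chloro-bearing compounds carry the chloro at other positions on the ring. Still, both compounds that bear a chloro on that ring sit higher than compound 3, and the exchange of a chlorophenyl for the methoxyphenyl gave the step of a 3.4-fold lower number from compound 1 to compound 3 (0.53 log units; beyond the scatter). The reverse exchange is therefore expected to raise the number, by an estimated 2.0-fold higher number from compound 3 to compound 4 (0.31 log units; beyond the scatter), with the chance that it stays within the scatter. Compound 4 is thus expected to give about 90 nm/s in this assay, within a range from 45 nm/s to 180 nm/s.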

Compound 4, apparent permeability in the ADME assay: 150 nm/s
Estimate against measurement, compound 4: 1.7-fold (0.22 log units) below, and the stated range covers the measured number.
By their numbers in the ADME assay, from the lowest: compounds 3, 2, 1 and 4 (each within the scatter of the next, the first and the last beyond it).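

With the ring position held fixed, the direct exchange of methoxy for chloro gives a 3.4-fold higher number from compound 3 to compound 4 (0.53 log units; beyond the scatter) in the ADME assay, so the gap seen earlier between compound 3 and compound 1 does not depend on moving the chloro to another position. The chlorophenyl compounds do not separate by chloro position, since no change at the digits printed from compound 1 to compound 4 (within the scatter) and a 1.9-fold higher number from compound 2 to compound 4 (0.28 log units; within the scatter) both stay within the scatter. In a physicochemical assay for solubility, measured as kinetic solubility (on this read-out higher numbers stand for higher solubility and lower numbers for lower solubility), compound 3 gives >= 113 ug/mL, which is a limit of the assay.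

In the physicochemical assay compound 4 gives >= 179 ug/mL, also a limit, so the step there cannot be read. How an amine or a carboxylic acid on this aromatic carbon would read in the ADME assay stays open, and nothing to hand accounts for the gap in the ADME assay.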